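The source may report more compounds than this note shows. Statements on the series, on what has been measured and on what is new or still open speak of the compounds shown alone.

Three compounds share one core and differ only in the group attached through the amide. Compound 1 `O=C(Nc1ccc(I)cc1)c1cncc(N2CC3CC(C2)N3)c1` carries a 4-iodophenyl there, and in an assay on membranes from Cerebral cortex for displacement of a labelled ligand from Neuronal acetylcholine receptor; alpha4/beta2 (Rattus norvegicus) (a lower number here means a stronger inhibitor, a higher number a weaker inhibitor), compound 1 gives 0.366 nM. Compound 2 `O=C(Nc1cccc(F)c1)c1cncc(N2CC3CC(C2)N3)c1` gives 0.044 nM, while compound 3 `O=C(c1cncc(N2CC3CC(C2)N3)c1)N1CCCc2ccccc21` gives 0.196 nM. Compound 1 shows the highest number of the three: compound 3 sits within the usual scatter of it, whereas compound 2 lies clearly apart, an 8.3-fold lower number from compound 1 to compound 2 (0.92 log units; beyond the scatter), where a 3-fluorophenyl replaces the 4-iodophenyl.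

Compound 4 `O=C(Nc1ccc(F)cc1)c1cncc(N2CC3CC(C2)N3)c1` keeps everything of compound 1 except one atom: fluoro in place of iodo on an aromatic carbon. Going by the values given here, only one measured step bears on this change, the one to compound 2, and it combined a swap of halogen with a shift of its place on the ring. Compound 4 keeps the place but swaps the halogen, so only part of that step should carry over. Compound 4 is therefore expected to show a lower number than compound 1, estimated as a 3.1-fold lower number from compound 1 to compound 4 (0.48 log units; beyond the scatter). The estimate for compound 4 in this assay is 0.12 nM, with a likely range from 0.04 nM to 0.4 nM.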

Compound 4, inhibition constant: 0.01 nM
Estimate against measurement, compound 4: 12-fold (1.08 log units) above; measured number below the stated range.
By their numbers in this assay, from the lowest: compound 4; then compound 2; then compounds 3 and 1 (each within the scatter of the next).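

Keeping the halogen in the same place and changing only iodo to fluoro gives a 37-fold lower number from compound 1 to compound 4 (1.56 log units; beyond the scatter) in this assay, so this single-atom change alone goes further than the combined step to compound 2 did. Fluoro is present on both sides of the next comparison, and moving from 3-fluorophenyl to 4-fluorophenyl gives a 4.4-fold lower number from compound 2 to compound 4 (0.64 log units; beyond the scatter) as a separate effect, showing that both the identity of the halogen and its place on the ring count here. No measurement shown gives a reason for either step.

Where a 4-chlorophenyl or a 4-bromophenyl would stand relative to compound 4 and compound 1 remains open, so a steady trend along the halogens cannot be judged. Also open, on these data alone, is how a methoxy group or an amine would fare at this place.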